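An Ethyl Group on the Amide of Compound 2

A few compounds are considered here, and "the series" means these few. Any claim that something is new, unique, unknown or untested is made for them only; others in the source may bear on it.

Compound 1 `COc1ccc2c(c1)OC(c1cc(OC)c(OC)c(OC)c1)C=C2` carries a hydrogen on a double-bonded ring carbon of the shared core. In a functional assay for inhibition of nuclear factor NF-kappa-B complex (Homo sapiens) (a higher number here means a weaker inhibitor, a lower number a stronger inhibitor), compound 1 gives 17700 nM. Compound 2 `COc1ccc2c(c1)OC(c1cc(OC)c(OC)c(OC)c1)C(C(N)=O)=C2` carries a carbamoyl group in that same place. In this assay compound 2 reaches only a limit of the assay, > 50000 nM, so a bound is known for it but not a number. Within the data shown here, the step of an at least 2.8-fold higher number from compound 1 to compound 2 (0.45 log units; beyond the scatter) is the only measured step here, and it rests on (the limit of > 50000 nM in this assay, at which 1 of the 2 values shown sits); compound 2 therefore stands as the weaker of the two, with its true value unknown.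

Compound 3 `CCNC(=O)C1=Cc2ccc(OC)cc2OC1c1cc(OC)c(OC)c(OC)c1` differs from compound 2 by ethyl in place of hydrogen on an amide-type nitrogen. Among the measured compounds shown here, no measured pair shows what an ethyl on an amide nitrogen does, so the expectation for compound 3 can lean only on compound 2 sitting at its limit and on an at least 2.8-fold higher number from compound 1 to compound 2 (0.45 log units; beyond the scatter) pointing toward weaker inhibition. The expected step that the limit leaves unreadable from compound 2 to compound 3 is thus barely any change. Compound 3 is estimated at 60000 nM, with a range from 20000 nM to 180000 nM, and it may well again be reported only as a limit.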

Compound 3, half-maximal inhibitory concentration: > 50000 nM
Compound 3 was reported as a limit; the forecaster's own chance of this, stated with the estimate: 70%; the middle value lies beyond the limit too.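

In this assay compound 3 is again reported only as a limit, > 50000 nM, so this second amide also gives no exact number. With ethylcarbamoyl in place of the hydrogen on the double-bonded ring carbon, the result is an at least 2.8-fold higher number from compound 1 to compound 3 (0.45 log units; beyond the scatter), so both amide groups shown at this position point toward weaker inhibition than the hydrogen. What the ethyl itself does on the amide nitrogen cannot be read, because compound 2 and compound 3 both stop at the same limit: the limit of > 50000 nM in this assay, at which 2 of the 3 values shown sit.

As far as these compounds go, the true values of compound 2 and compound 3 remain unknown, so these two cannot be ranked against each other. Also open, from the compounds shown here alone, is whether a carboxylic acid or an amine on that ring carbon, or a longer chain such as butyl on the amide nitrogen, would give a measurable number, and how that number would compare with compound 1 at 17700 nM.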